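A few compounds are considered here, and "the series" means these few. Any claim that something is new, unique, unknown or untested is made for them only; others in the source may bear on it.

Working notes on the thiosemicarbazone series.

Compound 1 `Fc1ccccc1NC(=S)N/N=C/c1ccc2ccccc2n1` is the anchor. In a functional assay on SGC-7901 cells (Homo sapiens) for antiproliferative activity, read by sulforhodamine B assay, with a stated time of 72 h (on this read-out lower numbers stand for stronger inhibition and higher numbers for weaker inhibition), compound 1 gives > 100000 nM, which is a limit of the assay and not a number. Compound 2 `NC(=S)N/N=C/c1nc2ccccc2s1` belongs to the same set. In this assay compound 2 gives > 100000 nM, again a limit rather than a number. On the numbers shown, compound 1 therefore stands only as a limit, and the single further value shown is a limit as well: the limit of > 100000 nM in this assay, at which 2 of the 2 values shown sit. Going by the values given here, no step between measured compounds can be drawn from this, since neither value is a number.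

The next compound is compound 3 `COc1ccccc1NC(=S)N/N=C/c1ccc2ccccc2n1`, not yet measured in this assay. Against compound 1 the change is methoxy in place of fluoro on an aromatic carbon.

Expectation: with both measured values sitting at the limit, the step from compound 1 to compound 3 is expected to be none beyond the scatter, a step that the limit leaves unreadable from compound 1 to compound 3, and the result most likely to come back as a limit again. Compound 3 is estimated at 150000 nM in this assay, within a range of 30000 nM to 500000 nM, the measurement itself being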

Compound 3, half-maximal inhibitory concentration: > 100000 nM
Compound 3 ended at the assay's limit; the forecaster's own chance of this, stated with the estimate: 80%; the middle value is on the limit's open side.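

Compound 1 and compound 3 both sit at a limit and not at a number, so no step can be read between them: the limit of > 100000 nM in this assay, at which 3 of the 3 values shown sit.

The compounds shown leave open whether 2-fluorophenyl and 2-methoxyphenyl differ at all in this assay, and what numeric value any of these compounds would give there.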